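The source may report more compounds than this note shows. Statements on the series, on what has been measured and on what is new or still open speak of the compounds shown alone.

Measured compounds:
compound 1, `CCc1cccc(C[C@H](O)/C=C/[C@H]2COC(=O)N2CCSCCCC(=O)O)c1`: 18 nM
compound 2, `COCc1cccc(C[C@H](O)/C=C/[C@H]2COC(=O)N2CCSCCCC(=O)O)c1`: 24 nM

Both compounds were tested in a functional assay on CHO cells for agonist activity at prostaglandin E2 receptor EP4 subtype (Rattus norvegicus), read by cAMP accumulation and immunoassay, with a stated time of 10 min; a higher number here means that more compound is needed for the effect, a lower number that less compound is needed. Compound 2 sits at one end of the two numbers shown, but the only step leading to it, a 1.3-fold higher number from compound 1 to compound 2 (0.12 log units; within the scatter), lies within the scatter, so the two values cannot be told apart. That step replaces a methyl with a methoxy on a saturated chain carbon attached to the aromatic ring, a change that barely registered.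

Compound 3, `O=C(O)CCCSCCN1C(=O)OC[C@@H]1/C=C/[C@@H](O)Cc1cccc(Cl)c1`, is not yet measured. It differs from compound 2 by chloro in place of methoxymethyl on an aromatic carbon. Among the compounds with values here, the one measured step that bears on this position is the swap from compound 1 to compound 2, which changed the group at the same place and stayed within the scatter. Within the data shown here, no measured step replaces a chain group on this ring with a single halogen, so the expectation rests on that one comparison alone. A step of a 1.2-fold lower number from compound 2 to compound 3 (0.08 log units; within the scatter) is therefore expected, with no change beyond the scatter in either direction. For compound 3 the estimate in this assay is 20 nM, in a range from 7 nM to 60 nM.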

Compound 3, half-maximal effective concentration: 23 nM
Beside the measured number, compound 3's estimate is 1.2-fold (0.06 log units) below it; measured number inside the range.
By their numbers in this assay, from the lowest: compounds 1, 3 and 2 (each within the scatter of the next).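

In this assay, this place on the aromatic ring now holds a single chlorine as well as the two chain groups, and neither new step rises above the scatter: methoxymethyl gives way to chloro (a 1.0-fold lower number from compound 2 to compound 3 (0.02 log units; within the scatter)), and ethyl gives way to chloro (a 1.3-fold higher number from compound 1 to compound 3 (0.11 log units; within the scatter)). Ethyl, methoxymethyl and chloro therefore cannot be told apart here, even though the change from 3-(methoxymethyl)phenyl to 3-chlorophenyl takes out 3 heavy atoms and 1 hydrogen-bond acceptor and puts in 1 heavy atom and no acceptor. Within the data shown here, the earlier pair compared only two chain groups, whereas this result extends the same flat reading to a halogen, for these three compounds only. Nothing available explains why the three values sit so close together.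

The compounds shown leave open whether an amine, a carboxylic acid or a longer chain at this place would also leave the number unmoved. They also leave open how another halogen, such as fluorine or bromine, would read, and whether chloro would read the same on a different carbon of the ring.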